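Amide methyl removal in the shared core: compound 4

This account rests on a few compounds, and the source may have more. Where it says the series, first, only, none or still open, it means among the compounds named here.

Measured in a functional assay for antagonist activity at C-X-C chemokine receptor type 3 (Homo sapiens); a lower number here means a stronger inhibitor, a higher number a weaker inhibitor:
- compound 1, `CNC(=O)c1cnc(N2CCN(C3CCN(Cc4ccc(Cl)cc4)CC3)[C@@H](C)C2)c(Cl)c1`: 32 nM
- compound 2, `CNC(=O)c1cnc(N2CCN(C3CCN(Cc4ccc(C)cc4)CC3)[C@@H](C)C2)c(Cl)c1`: 87 nM
- compound 3, `CNC(=O)c1cnc(N2CCN(C3CCN(Cc4ccc(F)cc4Cl)CC3)[C@@H](C)C2)c(Cl)c1`: 58 nM

Compound 1 gives the lowest of the three numbers. Its nearest neighbour is compound 3, reached by a 1.8-fold higher number from compound 1 to compound 3 (0.26 log units; within the scatter), a step that stays within the scatter; the step of a 2.7-fold higher number from compound 1 to compound 2 (0.43 log units; beyond the scatter) is the only one of the three that goes beyond it. The step of a 1.5-fold lower number from compound 2 to compound 3 (0.18 log units; within the scatter) is also within the scatter. All three measured compounds share the same core and the same methylcarbamoyl group; they differ only in the aryl ring on the saturated chain carbon bound to the amine nitrogen in a ring.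

Compound 4, `C[C@H]1CN(c2ncc(C(N)=O)cc2Cl)CCN1C1CCN(Cc2ccc(Cl)cc2)CC1`, keeps the 4-chlorophenyl of compound 1 and differs from it by hydrogen in place of methyl on an amide-type nitrogen. Within the data shown here, none of the measured steps touches this position, so no step bears directly on the change; the aryl variations give no guidance on the amide hydrogen. In the absence of any comparable step, the expected change from compound 1 to compound 4 is a 1.4-fold higher number from compound 1 to compound 4 (0.15 log units; within the scatter), not beyond the scatter, with a wide band to reflect that nothing measured supports it. Compound 4 is thus estimated at 45 nM in this assay, in a range from 15 nM to 140 nM.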

Compound 4, half-maximal inhibitory concentration: 39 nM
Compound 4: the middle estimate sits 1.2-fold (0.06 log units) above what was measured; low and high end bracket the measured number.
By their numbers in this assay, from the lowest: compounds 1, 4, 3 and 2 (each within the scatter of the next, the first and the last beyond it).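

In this assay, hydrogen in place of methyl on the amide-type nitrogen gives a 1.2-fold higher number from compound 1 to compound 4 (0.09 log units; within the scatter), so the methylcarbamoyl group of compound 1 and the carbamoyl group of compound 4 cannot be told apart by this read-out. Among these compounds, this is the first reading at this position, since compounds 1, 2 and 3 all carry the methylcarbamoyl group and differ only in the aryl ring; it shows that, with the 4-chlorophenyl kept, the methyl on the amide-type nitrogen can be lost without a step beyond the scatter. No supporting measurement is available to explain this result.

The compounds shown leave open whether the same swap stays within the scatter when the 4-chlorophenyl is replaced by the 4-methylphenyl of compound 2 or the 2-chloro-4-fluorophenyl of compound 3, since the single step here rests on one aryl group only. They also leave open how far this position tolerates other groups: an ethyl or a longer chain on the amide-type nitrogen, a second methyl on that nitrogen, or a carboxylic acid in place of the carbamoyl group would each test it further.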